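This account rests on a few compounds, and the source may have more. Where it says the series, first, only, none or still open, it means among the compounds named here.

Working notes on the series. In a functional assay on HepG2 cells (Homo sapiens) for cytotoxicity, read by MTT assay, with a stated time of 48 h (a higher number here means a weaker inhibitor, a lower number a stronger inhibitor), compound 1 `COc1cc(-c2nnc3n2NC(c2ccco2)C(C(=O)c2cccs2)S3)cc(OC)c1OC` gives 64100 nM, the only number shown for the set. Compound 2 `COc1cc(-c2nnc3n2NC(c2cccs2)C(C(=O)c2ccccc2)S3)cc(OC)c1OC` reaches a limit of this assay, > 100000 nM. Compound 3 `COc1cc(C(=O)C2Sc3nnc(-c4cc(OC)c(OC)c(OC)c4)n3NC2c2cccs2)cc(OC)c1OC` likewise sits at a limit, > 100000 nM. Among the compounds with values here, the one exchange on the carbonyl carbon with both ends measured, a step that the two limits leave unreadable from compound 2 to compound 3, gives no size, and the limit of > 100000 nM in this assay, at which 2 of the 3 values shown sit, holds two of the three values. Compound 4 `COc1cc(-c2nnc3n2NC(c2ccco2)C(C(=O)c2ccc(F)c(F)c2)S3)cc(OC)c1OC` differs from compound 1 by 3,4-difluorophenyl in place of thiophen-2-yl on a carbonyl carbon. Nothing measured fixes the direction of this exchange. Compound 4 is therefore expected to show a 1.1-fold higher number from compound 1 to compound 4 (0.04 log units; within the scatter), no step beyond the scatter. The estimate for compound 4 in this assay is 70000 nM, ranging from 25000 nM to 200000 nM.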

Compound 4, half-maximal inhibitory concentration: 52400 nM
The estimate for compound 4 lay 1.3-fold (0.13 log units) above the measured number; measured number inside the range.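

Within the data shown here, on the carbonyl carbon, the first readable step in this assay is a 1.2-fold lower number from compound 1 to compound 4 (0.09 log units; within the scatter). Thiophen-2-yl and 3,4-difluorophenyl, a five-membered aromatic ring with one hetero atom and a six-membered aromatic ring of carbon only, are therefore not told apart at this position on the core of compound 1.

Going by these compounds, the size of any step involving the remaining values stays unreadable, since these are limits of the assay and not numbers: the limit of > 100000 nM in this assay, at which 2 of the 4 values shown sit. Also open is how an amine or a carboxylic acid on this carbonyl carbon would read.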